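Cytotoxicity of a Purine Series: Replacing Furan with Oxolane

This account rests on a few compounds, and the source may have more. Where it says the series, first, only, none or still open, it means among the compounds named here.

In an ADME assay on NHDF cells (Homo sapiens) for cytotoxicity, read by neutral red uptake, with a stated time of 24 h, tested at 3.9 uM (a higher number here means a stronger effect of the compound at the concentration tested, a lower number a weaker effect), three compounds have been measured. Compound 1 `c1csc(CNc2ncnc3c2ncn3C2CCCO2)c1` gives 100% and compound 2 `OCc1ccc(CNc2ncnc3c2ncn3C2CCCO2)o1` gives 103%. Compound 3 `Clc1nc(NCc2ccco2)c2ncn(C3CCCO3)c2n1` gives 100%, level with compound 1 at the digits shown and together with it the lowest of the three numbers, while compound 2 sits a few points higher, all within the scatter. Compound 4 `Clc1nc(NCC2CCCO2)c2ncn(C3CCCO3)c2n1` is the unmeasured analogue. Its change from compound 3 is oxolan-2-yl in place of furan-2-yl on a saturated chain carbon bound to a nitrogen on an aromatic ring. For the measured compounds named here, the only measured step at the same place, a number 3 percentage points higher from compound 1 to compound 2 (within the scatter), swapped one aromatic ring for another and moved the number by no more than the scatter. That step gives a hint, not a rule: it never tested a non-aromatic ring. Since all three measured values cluster at the same high level, the change to compound 4 is expected to bring a number 1 percentage points lower from compound 3 to compound 4 (within the scatter), no movement beyond the scatter. Compound 4 is therefore estimated at 99%, within a range from 87% to 108%.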

Compound 4, a percentage reported as activity, at one concentration (the size of the read-out at that concentration, not a potency): 103%
For compound 4 the middle estimate is 4 percentage points below the measured one; measured number inside the range.
By their numbers in this assay, from the lowest: compounds 1, 3, 2 and 4 (each within the scatter of the next).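

For the compounds shown here, this step is the first at this position to leave the aromatic rings behind: in this assay, the non-aromatic oxolan-2-yl replaces the aromatic furan-2-yl, giving a number 3 percentage points higher from compound 3 to compound 4 (within the scatter). On a saturated chain carbon bound to a nitrogen on an aromatic ring, this pair therefore shows no difference beyond the scatter when a five-membered aromatic ring gives way to a non-aromatic one of the same heavy-atom count. Nothing available explains this result.

It remains open whether a carboxylic acid, an amine or a longer chain at this place would also stay within the scatter of these compounds. The read-out also comes from a single concentration, so it cannot show whether compound 3 and compound 4 would differ at lower concentrations.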